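Capping the Remaining Hydroxy Group with a Second Pyrazine Ether

A few compounds are considered here, and "the series" means these few. Any claim that something is new, unique, unknown or untested is made for them only; others in the source may bear on it.

Compound 1 `COc1cc(CNC(=O)/C=C/c2ccccc2)ccc1OCc1nc(C)c(C)nc1C`: 7310 nM in a functional assay on SH-SY5Y cells (Homo sapiens) for cytotoxicity, read by MTT assay, with stated times of 24 h and 4 h; a lower number here means that less compound is needed, a higher number that more compound is needed for the effect
Compound 2 `COc1cc(CNC(=O)/C=C/c2ccccc2O)ccc1O`: 9760 nM in this assay
Compound 3 `COc1cc(CNC(=O)/C=C/c2ccccc2OCc2nc(C)c(C)nc2C)ccc1O`: 12000 nM in this assay

Compound 3 carries the highest of the three numbers, but both neighbours lie within the scatter of it, so the three compounds cannot be ranked against one another. Compound 4 `COc1cc(CNC(=O)/C=C/c2ccccc2OCc2nc(C)c(C)nc2C)ccc1OCc1nc(C)c(C)nc1C` differs from compound 3 by (3,5,6-trimethylpyrazin-2-yl)methyl in place of hydrogen on an oxygen on an aromatic ring. Among the compounds with values here, the only measured step that bears on this change, a 1.2-fold higher number from compound 2 to compound 3 (0.09 log units; within the scatter), placed the same group on the other aromatic oxygen and left the number essentially where it was. Compound 4 is therefore expected to show no step beyond the scatter in this assay, no change at the digits printed from compound 3 to compound 4 (within the scatter). The estimate for compound 4 is 12000 nM, with a range from 6000 nM to 25000 nM.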

Compound 4, half-maximal effective concentration: 6280 nM
Compound 4: middle estimate off by 1.9-fold (0.28 log units), on the high side; the range from low to high includes it.
By their numbers in this assay, from the lowest: compounds 4, 1, 2 and 3 (each within the scatter of the next).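

In this assay the change from hydroxy to (3,5,6-trimethylpyrazin-2-yl)methoxy at this oxygen gives a 1.9-fold lower number from compound 3 to compound 4 (0.28 log units; within the scatter) and so adds no readable change, even with a second pyrazine ring now on the molecule. Placing (3,5,6-trimethylpyrazin-2-yl)methoxy on the aromatic carbon of compound 1 gives a 1.2-fold lower number from compound 1 to compound 4 (0.07 log units; within the scatter) and likewise shows that this position accepts the group without a readable shift. Nothing measured here accounts for these numbers. On these data alone, whether a group of another kind on this oxygen, such as an amine or a carboxylic acid, would produce a step beyond the scatter remains open.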